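Aryl-linked alkanoic acids: dropping the hexyl branch

The source may hold more compounds than are shown below. What is called first, only, known or untested is meant among the compounds shown, and "the series" means these compounds.

Measured to date:
compound 1 `Cc1ccc(C)c(NCCCC(C)(C)C(=O)O)c1`, in a functional assay on thoracic aorta (Mus musculus, strain C57Bl6) for inhibition (on this read-out higher numbers stand for an effect only at larger amounts of compound and lower numbers for an effect already at smaller amounts), compound 1 gives 100 uM;
compound 2 `CCCCCCC(CCCOc1cc(C)ccc1C)C(=O)O`, in this assay compound 2 gives 10 uM;
compound 3 `Cc1ccc(C)c(N(CCCC(C)(C)C(=O)O)C(=O)CCCCC(=O)N(CCCC(C)(C)C(=O)O)c2cc(C)ccc2C)c1`, in this assay compound 3 gives 10 uM.

Compound 2 stands level with compound 3 at the digits shown, the two together giving the lowest numbers of the three; compound 1 sits a full order above it, beyond the scatter. Compound 4 `Cc1ccc(C)c(OCCCCC(=O)O)c1` differs from compound 2 by hydrogen in place of hexyl on a saturated chain carbon bound to a carbonyl carbon and a saturated chain carbon. For the measured compounds named here, no measured pair reports this change, so its size is open. Because compound 2 gives 10 uM with the hexyl in place, the expectation is a moderate rise in number after its removal, a step of a 3.0-fold higher number from compound 2 to compound 4 (0.48 log units; beyond the scatter). For compound 4 the estimate in this assay is 30 uM, within 10 uM to 100 uM.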

Compound 4, minimum effective concentration: 100 uM
Compound 4: the middle estimate sits 3.3-fold (0.52 log units) below what was measured, within the range that was stated.
By their numbers in this assay, from the lowest: compounds 2 and 3 (each within the scatter of the next); then compounds 1 and 4 (each within the scatter of the next).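

In this assay, for the compounds shown here, hydrogen in place of hexyl on a saturated chain carbon bound to a carbonyl carbon and a saturated chain carbon gives a 10-fold higher number from compound 2 to compound 4 (1.00 log units; beyond the scatter) in the only one-place change read so far. The hexyl at this position therefore matters to the read-out, and its loss is not a change within the scatter. Nothing at hand accounts for the size of this step.

Open: whether a shorter chain such as propyl at this carbon already restores the number of compound 2. Also open, from the compounds shown here alone, is whether a longer chain such as octyl, or a phenyl ring there, lowers it further.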